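The source may hold more compounds than are shown below. What is called first, only, known or untested is meant among the compounds shown, and "the series" means these compounds.

Measured so far in a functional assay on OVCAR-3 cells (Homo sapiens) for antiproliferative activity, read by sulforhodamine B assay, with a stated time of 48 h; a higher number here means a weaker inhibitor of growth, a lower number a stronger inhibitor of growth:
compound 1 `CCCCCCCCCCCCCCCCCC(=O)N1CCOCC1` gives 43.3 ug/mL;
compound 2 `CCCCCCCCCCCCCCCC(=O)N1CCCC1` gives 6.3 ug/mL;
compound 3 `CCCCCCCCCCCCCCCC(=O)N1CCOCC1` gives 33.1 ug/mL.

Compound 2 has the lowest number of the three and so is the strongest growth inhibitor here; its nearest neighbour is compound 3, with a 5.3-fold higher number from compound 2 to compound 3 (0.72 log units; beyond the scatter), and compound 1 sits further off. Compound 4 `CCCCCCCCCCCCCCCCCC(=O)N1CCCC1` is compound 2 with a single change: ethyl in place of hydrogen on a saturated chain carbon, ten or more bonds along the chain from a carbonyl carbon. Among the compounds with values here, the only measured step of this kind runs the other way, in the pair carrying morpholin-4-yl, where a 1.3-fold lower number from compound 1 to compound 3 (0.12 log units; within the scatter). That step lay within the scatter, so for compound 4 only a small change is expected in this assay, with no clear direction. Compound 4 is therefore estimated at 8 ug/mL, in a range from 3 ug/mL to 20 ug/mL. The expected step is a 1.3-fold higher number from compound 2 to compound 4 (0.10 log units; within the scatter), within the scatter.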

Compound 4, concentration for 50% growth inhibition: 7.3 ug/mL
Beside the measured number, compound 4's estimate is 1.1-fold (0.04 log units) above it, within the range that was stated.
By their numbers in this assay, from the lowest: compounds 2 and 4 (each within the scatter of the next); then compounds 3 and 1 (each within the scatter of the next).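

In this assay, ethyl in place of hydrogen on a saturated chain carbon, ten or more bonds along the chain from a carbonyl carbon, gives a 1.2-fold higher number from compound 2 to compound 4 (0.06 log units; within the scatter), so this chain change now stays small with pyrrolidin-1-yl as well as with morpholin-4-yl: the same change on two cores in this assay, a 1.3-fold lower number (0.12 log units; within the scatter) from compound 1 to compound 3 and a 1.2-fold lower number (0.06 log units; within the scatter) from compound 4 to compound 2, 1.1-fold (0.05 log units) apart, within the scatter of two such steps

Pyrrolidin-1-yl in place of morpholin-4-yl gives a 5.9-fold lower number from compound 1 to compound 4 (0.77 log units; beyond the scatter), so this swap carries over to the longer chain: the same change on two cores in this assay, a 5.3-fold higher number (0.72 log units; beyond the scatter) from compound 2 to compound 3 and a 5.9-fold higher number (0.77 log units; beyond the scatter) from compound 4 to compound 1, 1.1-fold (0.05 log units) apart, within the scatter of two such steps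

The compounds shown leave open whether piperidin-1-yl on the carbonyl carbon would behave like pyrrolidin-1-yl or like morpholin-4-yl, and whether a much shorter chain would keep the same pattern.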